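A few compounds are considered here, and "the series" means these few. Any claim that something is new, unique, unknown or untested is made for them only; others in the source may bear on it.

Of the compounds shown here, two with a shared core have been measured so far in a functional assay on THP-1 cells (Homo sapiens) for cytotoxicity, read by MTT assay, with a stated time of 24 h; on this read-out higher numbers stand for weaker inhibition and lower numbers for stronger inhibition. Compound 1 `COc1cc(/C=C2\CN(C)C/C(=C\c3ccccc3F)C2=O)cc(OC)c1` gives 1170 nM, and compound 2 `COc1cc(/C=C2\CN(C)C/C(=C\c3ccccc3F)C2=O)cc(OC)c1OC` gives 640 nM. Among the measured compounds shown here, these are the only two numbers available, and they lie within the scatter of each other, so neither compound can be ranked over the other.

The next structure is compound 3 `COc1cc(/C=C2\CN(C)C/C(=C\c3cc(OC)c(OC)c(OC)c3)C2=O)cc(OC)c1`, which differs from compound 2 in one place: 3,5-dimethoxyphenyl in place of 2-fluorophenyl on a double-bonded chain carbon bound to a double-bonded ring carbon. In words, 3,5-dimethoxyphenyl stands in place of 2-fluorophenyl on a double-bonded chain carbon bound to a double-bonded ring carbon.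

For the measured compounds named here, only one measured step bears on this change: a 1.8-fold lower number from compound 1 to compound 2 (0.26 log units; within the scatter). That step put methoxy in place of hydrogen on an aromatic carbon and stayed within the scatter. Going by the values given here, it offers only indirect guidance, since no measured step removes the 2-fluorophenyl. No step beyond the scatter is therefore expected in this assay, in either direction. The expected change is a 1.2-fold higher number from compound 2 to compound 3 (0.07 log units; within the scatter). For compound 3 the estimated value is 750 nM, with an expected range from 250 nM to 2200 nM.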

Compound 3, half-maximal inhibitory concentration: 720 nM
Beside the measured number, compound 3's estimate is 1.0-fold (0.02 log units) above it; the range from low to high includes it.
By their numbers in this assay, from the lowest: compounds 2, 3 and 1 (each within the scatter of the next).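

In this assay, putting 3,5-dimethoxyphenyl in place of 2-fluorophenyl on a double-bonded chain carbon bound to a double-bonded ring carbon gives a 1.1-fold higher number from compound 2 to compound 3 (0.05 log units; within the scatter). Among the compounds shown here, the earlier step involved a different place, so this is the first sign that this position can lose the fluorine and take a group of 10 heavy atoms instead of 7, with 2 hydrogen-bond acceptors instead of none, without the number moving beyond the scatter. The data offer no measurement that explains why the number holds across so large a swap in the group, so this remains an observation only.

All three compounds carry a substituted phenyl at this position, and only fluorine and methoxy appear on it, so the result says nothing about how a quite different group there, such as an amine, a carboxylic acid or a longer chain, would behave. For the compounds shown here, it also remains open whether any change at this position can move the number beyond the scatter in either direction, since every step so far lies within it.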